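The source may report more compounds than this note shows. Statements on the series, on what has been measured and on what is new or still open speak of the compounds shown alone.

Going by the values given here, in an ADME assay on A549 cells (Homo sapiens) for cytotoxicity, read by CCK-8 assay, with a stated time of 48 h (on this read-out higher numbers stand for lower toxicity in this test and lower numbers for higher toxicity in this test), compound 2 `O=C(CNc1nc(N2CCCC2)nc2ccccc12)Nc1ccc2ccccc2c1` gives 4770 nM, the only actual number in this small set. Compound 1 `CCN(CC)c1nc(SCC(=O)Nc2ccccc2)c2ccccc2n1`, also with phenyl on an amide-type nitrogen, reports only a limit, > 100000 nM. Compound 3 `CCN(CC)c1nc(NCC(=O)NCc2ccccc2)c2ccccc2n1` likewise reports only a limit, > 100000 nM. Compound 4 `O=C(CNc1nc(N2CCCC2)nc2ccccc12)Nc1ccccc1` carries phenyl in place of naphthalen-2-yl on an amide-type nitrogen. Among the compounds with values here, no measured pair isolates this change, so the expectation is loose. A rise in this assay beyond the scatter, towards lower toxicity, is expected, resting on compound 1 with its limit > 100000 nM and on (the limit of > 100000 nM in this assay, at which 2 of the 3 values shown sit). The expected size is a 6.3-fold higher number from compound 2 to compound 4 (0.80 log units; beyond the scatter). For compound 4 the estimated value is 30000 nM, with an expected range of 9000 nM to 100000 nM.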

Compound 4, half-maximal cytotoxic concentration: 19000 nM
Compound 4: middle estimate off by 1.6-fold (0.20 log units), on the high side, and the stated range covers the measured number.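

Going by these compounds alone, on the amide-type nitrogen whose other neighbour is the carbonyl carbon, phenyl in place of naphthalen-2-yl gives the first measured step in this assay: a 4.0-fold higher number from compound 2 to compound 4 (0.60 log units; beyond the scatter). In this one pair, going from two aromatic rings to one moves the read-out towards lower toxicity in this test. Compound 4 still gives a number rather than a limit, which sets it apart from the limit values in this set: the limit of > 100000 nM in this assay, at which 2 of the 4 values shown sit.

From the compounds shown here alone, whether the step holds for a phenyl carrying a carboxylic acid or an amine remains open. Compound 1 and compound 3 differ from compound 4 in more than one place, so they do not show what the rest of the structure contributes.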